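The source may hold more compounds than are shown below. What is called first, only, known or untested is meant among the compounds shown, and "the series" means these compounds.

Compound 1 `COc1cc(C(=O)c2sc(-c3cccs3)cc2N)cc(OC)c1OC` and compound 2 `COc1cc(C(=O)c2sc(-c3ccc(I)cc3)cc2N)cc(OC)c1OC` share the same core and differ only in the aromatic group hung on it. In a functional assay on FM3A cells (Mus musculus) for antiproliferative activity (on this read-out higher numbers stand for weaker inhibition and lower numbers for stronger inhibition), compound 1 gives 1.7 nM, while in this assay compound 2 gives 420 nM. Going by the values given here, of the two numbers measured so far, compound 1 stands at the lowest, making it the stronger inhibitor of the pair. Among the compounds with values here, the single measured step, a 250-fold higher number from compound 1 to compound 2 (2.39 log units; beyond the scatter), shows that replacing the thiophen-2-yl with a 4-iodophenyl weakens inhibition sharply.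

Compound 3 `COc1cc(C(=O)c2sc(-c3ccc(Br)cc3)cc2N)cc(OC)c1OC` has not yet been measured. It differs from compound 1 by 4-bromophenyl in place of thiophen-2-yl on an aromatic carbon, the new group sitting next to the ring sulfur, two ring bonds from the ring atom that bears an amino group. The step from compound 1 to compound 2 bears directly on this change, since a 4-bromophenyl and a 4-iodophenyl are both halogen-bearing six-membered rings of carbon only taking the place of the same five-membered ring. A large rise in the number is therefore expected, roughly a 150-fold higher number from compound 1 to compound 3 (2.17 log units; beyond the scatter). Compound 3 is thus estimated at 250 nM in this assay, with a range from 50 nM to 1200 nM.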

Compound 3, half-maximal inhibitory concentration: 150 nM
Beside the measured number, compound 3's estimate is 1.7-fold (0.22 log units) above it; measured number inside the range.
By their numbers in this assay, from the lowest: compound 1; then compound 3; then compound 2.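

Compound 3 shows that the large loss at this position is not peculiar to the iodo compound: with 4-bromophenyl in place of thiophen-2-yl, the read-out moves by an 88-fold higher number from compound 1 to compound 3 (1.95 log units; beyond the scatter) and so a second halogen-bearing phenyl also falls far behind the thiophen-2-yl of compound 1. The halogen itself also counts, since bromo in place of iodo gives a 2.8-fold lower number from compound 2 to compound 3 (0.45 log units; beyond the scatter) and this modest gain in inhibition is small beside the gap that remains to compound 1. The ring at this position therefore goes with the larger difference among these three compounds, while the halogen on the phenyl adjusts the number within that weaker range, though no measurement at hand explains either difference.

Every six-membered ring shown here carries a halogen, so the compounds cannot separate the effect of replacing thiophen-2-yl with phenyl from the effect of the halogen on it. Plain phenyl would address that question, while 4-chlorophenyl, 4-methoxyphenyl or furan-2-yl at the same place would show how far the trend among these compounds extends.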